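The source may report more compounds than this note shows. Statements on the series, on what has been measured and on what is new or still open speak of the compounds shown alone.

Compound 3, `CCN(CC)CC(=O)Nc1ccc(-c2nc3cc(C(F)(F)F)ccc3n2C)cc1`, is one of three compounds tested in an ADME assay on MDBK cells (Bos taurus) for cytotoxicity, read by MTT assay, with a stated time of 96 h; on this read-out lower numbers stand for higher toxicity in this test and higher numbers for lower toxicity in this test. In this assay compound 3 gives 57000 nM, the highest number of the three. The nearest value belongs to compound 2, `COc1ccc(-c2nc3cc(Cl)c(Cl)cc3[nH]2)c(N)c1`, which in this assay gives 6500 nM, a lower number than compound 3 by a margin beyond the usual scatter. Furthest from compound 3 stands compound 1, `COc1ccc(-c2nc3cc(C(F)(F)F)ccc3[nH]2)c(N)c1`, which in this assay gives 4000 nM, again a lower number beyond the scatter. Compound 3 is thus the least toxic of the three on this read-out.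

Compound 4, `Cn1c(-c2ccc(NC(=O)CN3CCCCC3)cc2)nc2cc(C(F)(F)F)ccc21`, has not yet been measured in this assay. It differs from compound 3 in one place: piperidin-1-yl in place of diethylamino on a saturated chain carbon bound to a carbonyl carbon. The groups that leave and enter are both saturated amines of closely similar size, and the carbonyl, the amide and the rest of the shared core are unchanged. No pair of measured compounds isolates this kind of change, so nothing among the numbers shown speaks for a shift in either direction.

The step from compound 3 to compound 4 in this assay is expected to be a 1.1-fold lower number from compound 3 to compound 4 (0.06 log units; within the scatter), that is, no step beyond the scatter. Compound 4 is accordingly estimated to give 50000 nM in this assay, within a range of 20000 nM to 120000 nM.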

Compound 4, half-maximal cytotoxic concentration: 100000 nM
Estimate against measurement, compound 4: 2.0-fold (0.30 log units) below; the range from low to high includes it.
By their numbers in this assay, from the lowest: compounds 1 and 2 (each within the scatter of the next); then compounds 3 and 4 (each within the scatter of the next).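

In this assay, within the data shown here, piperidin-1-yl in place of diethylamino on a saturated chain carbon bound to a carbonyl carbon gives a 1.8-fold higher number from compound 3 to compound 4 (0.24 log units; within the scatter), the first step in this set between compounds that differ in one place. At this position, then, an open-chain amine and a six-membered non-aromatic ring with one hetero atom cannot be told apart on this read-out, and both compounds remain in the upper pair of the four, separate from compounds 1 and 2. No measurement at hand bears on why the two amines read alike.

As far as these compounds go, what remains open is whether this holds for groups further from these two, such as a morpholine ring, a primary amine, a carboxylic acid or a longer chain between the carbonyl and the amine. Compounds 1 and 2 differ from compounds 3 and 4 in more than one place, so the compounds shown do not assign the gap between the two pairs to the (((piperidin-1-yl)methyl)carbonyl)amino group or to any other single part of the structure.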